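The source may report more compounds than this note shows. Statements on the series, on what has been measured and on what is new or still open speak of the compounds shown alone.

Measured in a functional assay on A-375 cells (Homo sapiens) for antiproliferative activity; a lower number here means a stronger inhibitor, a higher number a weaker inhibitor:
- compound 1 `O=C(Nc1ccc(-c2ncc[nH]2)cc1)C1CCCN(Cc2ccc(F)c(F)c2)C1`: 19000 nM
- compound 2 `O=C(Nc1ccc(-c2ccsc2)cc1)C1CCCN(Cc2ccc(F)c(F)c2)C1`: 950 nM

Compound 2 holds the lower of the two numbers. Compound 3 `O=C(Nc1ccc(-c2ccc[nH]2)cc1)C1CCCN(Cc2ccc(F)c(F)c2)C1` has 1H-pyrrol-2-yl in place of thiophen-3-yl on an aromatic carbon. Among the measured compounds shown here, one measured step bears on this: a 20-fold lower number from compound 1 to compound 2 (1.30 log units; beyond the scatter), large and beyond the scatter, with thiophen-3-yl in place of 1H-imidazol-2-yl. The entering ring resembles the 1H-imidazol-2-yl of compound 1 more closely than thiophen-3-yl does, so a rise in this assay is expected, covering only part of that step. The expected change is a 2.6-fold higher number from compound 2 to compound 3 (0.42 log units; beyond the scatter). Compound 3 is estimated at 2500 nM, with a range of 800 nM to 9000 nM.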

Compound 3, half-maximal inhibitory concentration: 360 nM
The estimate for compound 3 lay 6.9-fold (0.84 log units) above the measured number; the whole stated range lies above it.
By their numbers in this assay, from the lowest: compound 3; then compound 2; then compound 1.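

In this assay the change to 1H-pyrrol-2-yl gives a 2.6-fold lower number from compound 2 to compound 3 (0.42 log units; beyond the scatter) and shows that, at this place para to a large group, a ring carrying a hydrogen-bond donor can outperform thiophen-3-yl. The comparison with the imidazole gives a 53-fold lower number from compound 1 to compound 3 (1.72 log units; beyond the scatter) and separates two similar rings by a large margin, so the high number of compound 1 is not shared by every nitrogen-hydrogen ring. No measurement here accounts for either step.

Open, on these data alone, is whether furan-2-yl or 1H-pyrrol-3-yl would track compound 3 or compound 2 at this place, and whether an N-methylpyrrole would keep the number of compound 3.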